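The source may report more compounds than this note shows. Statements on the series, on what has been measured and on what is new or still open speak of the compounds shown alone.

Measured in a functional assay on the whole organism (strain Swiss albino) for inhibition, with Mus musculus as the target, in the writhing test, with stated times of 60 min and 15 min, at a dose of 100 mg/kg by the oral route; on this read-out higher numbers stand for more inhibition at the one dose given (going by the name of the read-out) and lower numbers for less inhibition:
compound 1 `CNC(=O)CC1CCc2cc(OC)c(OC)cc21`: 21.2%
compound 2 `COc1cc2c(cc1OC)C(CC(=O)NC(C)C)CC2`: 29.3%
compound 3 `COc1cc2c(cc1OC)C(CC(=O)NC1CCCCC1)CC2`: 44.7%

Going by the values given here, compound 1 carries the lowest of the three figures, but the step of a number 8.1 percentage points higher from compound 1 to compound 2 (within the scatter) is within the scatter, so compounds 1 and 2 cannot be separated; only the step of a number 23.5 percentage points higher from compound 1 to compound 3 (beyond the scatter) is beyond it. The step of a number 15.4 percentage points higher from compound 2 to compound 3 (beyond the scatter) is also beyond the scatter.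

Compound 4 `COc1cc2c(cc1OC)C(CC(=O)N1CCCCC1)CC2` is not yet measured in this assay. Relative to compound 1 the change is piperidin-1-yl in place of methylamino on a carbonyl carbon. Of the measured steps, the one most like it is the change from methyl to cyclohexyl on the amide-type nitrogen, a number 23.5 percentage points higher from compound 1 to compound 3 (beyond the scatter), since a six-membered ring enters in both cases; the isopropyl step a number 8.1 percentage points higher from compound 1 to compound 2 (within the scatter) was smaller. Among the compounds with values here, no measured pair shows a hydrogen-bond donor leaving the amide-type nitrogen, so that part of the change is uncovered. A modest rise in this assay is therefore expected for compound 4, smaller than the cyclohexyl step, as a number 13.8 percentage points higher from compound 1 to compound 4 (beyond the scatter). The expected value for compound 4 is 35%, with a range from 20% to 52%.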

Compound 4, a percentage reported as inhibition, in the whole organism at one dose (the size of the read-out at that dose, not a potency): 44.7%
Estimate against measurement, compound 4: 9.7 percentage points below; the range from low to high includes it.
By their numbers in this assay, from the lowest: compounds 1 and 2 (each within the scatter of the next); then compounds 3 and 4 (each within the scatter of the next).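

In this series (this assay), the amide hydrogen can go without a visible loss: piperidin-1-yl in place of cyclohexylamino gives (no change at the digits printed from compound 3 to compound 4 (within the scatter)). The rise over the smaller groups also remains without that hydrogen (a number 23.5 percentage points higher from compound 1 to compound 4 (beyond the scatter); a number 15.4 percentage points higher from compound 2 to compound 4 (beyond the scatter)), so among these four compounds the two carrying a six-membered ring share the higher level, whether the ring is attached through the amide hydrogen-bearing nitrogen or contains that nitrogen. No evidence at hand explains this result.

From the compounds shown here alone, whether the ring itself matters, or only the number of carbons on the nitrogen, remains open; a diethylamino group on the carbonyl carbon would test this. Going by these compounds, the effect of a ring hetero atom beyond the amide nitrogen also remains open, and morpholin-4-yl would address it.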